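A Ring Nitrogen Enters the Aryl Group of Compound 1

The source may hold more compounds than are shown below. What is called first, only, known or untested is meant among the compounds shown, and "the series" means these compounds.

Measured compounds:
compound 1, `CC(C)(C)CC[C@H](c1ccc(C(=O)NCc2nn[nH]n2)cc1)N1C(=O)C(c2cccc(C(F)(F)F)c2)=N[C@]12CC[C@@H](C(C)(C)C)CC2`, 140 nM
compound 2, `CCCCC[C@H](c1ccc(C(=O)NCc2nn[nH]n2)cc1)N1C(=O)C(c2cc(Cl)cc(Cl)c2)=N[C@]12CC[C@@H](C(C)(C)C)CC2`, 310 nM
compound 3, `C[C@H](c1ccc(C(=O)NCCC(=O)O)cc1)N1C(=O)C(c2cccc(Cl)c2F)=N[C@]12CC[C@@H](C(C)(C)C)CC2`, 4000 nM

Of the compounds shown here, three sharing one core have been measured in an assay on membranes from liver for displacement of a labelled ligand from Glucagon receptor (Mus musculus), read by scintillation counting, with a stated time of 60 min; a higher number here means a weaker inhibitor, a lower number a stronger inhibitor. Compound 1 gives the lowest number of the three, 140 nM. Its nearest neighbour, compound 2, gives 310 nM, a gap that lies beyond the usual scatter, and compound 3 gives 4000 nM, far beyond it. Compound 1 is therefore the strongest inhibitor of the three in this assay.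

Compound 4, `CC(C)(C)CC[C@H](c1ccc(C(=O)NCc2nn[nH]n2)cc1)N1C(=O)C(c2cnccc2C(F)(F)F)=N[C@]12CC[C@@H](C(C)(C)C)CC2`, has not yet been measured. It differs from compound 1 in one place: 4-(trifluoromethyl)pyridin-3-yl in place of 3-(trifluoromethyl)phenyl on a carbon with a double bond to nitrogen. Among the measured compounds shown here, no pair of measured compounds differing in one place exists here, so the size of such a change cannot be read from the data. Since the change keeps the trifluoromethyl and adds only a ring nitrogen, the step of a 1.8-fold higher number from compound 1 to compound 4 (0.25 log units; within the scatter) is expected to be small, toward a weaker inhibitor but possibly within the scatter. For compound 4 the expected value in this assay is 250 nM, with a range from 80 nM to 800 nM.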

Compound 4, half-maximal inhibitory concentration: 96 nM
Estimate against measurement, compound 4: 2.6-fold (0.42 log units) above; low and high end bracket the measured number.
By their numbers in this assay, from the lowest: compounds 4 and 1 (each within the scatter of the next); then compound 2; then compound 3.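

In this assay, among the compounds shown here, putting 4-(trifluoromethyl)pyridin-3-yl in place of 3-(trifluoromethyl)phenyl gives a 1.5-fold lower number from compound 1 to compound 4 (0.16 log units; within the scatter), the first step at this position that can be read. This position on a carbon with a double bond to nitrogen therefore accepts a ring nitrogen, with its hydrogen-bond acceptor, without a difference that stands out from the scatter, although the step covers the exchange of the whole group and cannot be divided between the ring nitrogen and the changed place of the trifluoromethyl. Nothing available bears on why the two groups read alike.

Going by these compounds, it remains open whether a pyridin-3-yl group carrying a nitrile or a chlorine in place of the trifluoromethyl would read the same. Also open, on these data alone, is how a pyridin-3-yl group with no trifluoromethyl at all would compare.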